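The source may hold more compounds than are shown below. What is called first, only, known or untested is meant among the compounds shown, and "the series" means these compounds.

Measured compounds:
compound 1 `O=C(NC1CCCCC1)c1cc(Oc2ccc(/C=C/c3ccccn3)cc2)ccn1` — 12500 nM
compound 2 `O=C(NCc1ccc(F)cc1)c1cc(Oc2ccc(/C=C/c3ccncc3)cc2)ccn1` — 18200 nM

In a functional assay on A549 cells (Homo sapiens) for antiproliferative activity, read by CCK-8 assay, with a stated time of 48 h (on this read-out lower numbers stand for stronger inhibition and higher numbers for weaker inhibition), compound 1 gives 12500 nM. In this assay compound 2 gives 18200 nM, the higher of the two numbers, though the gap to compound 1 lies within the scatter. Compound 3 `O=C(NC1CCCCC1)c1cc(Oc2ccc(/C=C/c3ccncc3)cc2)ccn1` differs from compound 2 by cyclohexyl in place of 4-fluorobenzyl on an amide-type nitrogen. Among the compounds with values here, no pair of measured compounds differs in this one place, so the size of the step is not known from the data. Compound 3 is expected to stay close to compound 2, with a step of a 1.2-fold lower number from compound 2 to compound 3 (0.08 log units; within the scatter) of no more than the scatter. Compound 3 is estimated at 15000 nM, between 6000 nM and 40000 nM.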

Compound 3, half-maximal inhibitory concentration: 16800 nM
Beside the measured number, compound 3's estimate is 1.1-fold (0.05 log units) below it; the range from low to high includes it.
By their numbers in this assay, from the lowest: compounds 1, 3 and 2 (each within the scatter of the next).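

In this assay, cyclohexyl in place of 4-fluorobenzyl on the amide-type nitrogen gives a 1.1-fold lower number from compound 2 to compound 3 (0.03 log units; within the scatter), so this place takes a non-aromatic ring or a benzyl group with no change beyond the scatter. Pyridin-4-yl in place of pyridin-2-yl gives a 1.3-fold higher number from compound 1 to compound 3 (0.13 log units; within the scatter), also within the scatter, so neither change has yet shown a measurable effect. Nothing available bears on the reason for these small steps. Going by these compounds, whether a carboxylic acid or an amine on the amide-type nitrogen would move the number beyond the scatter remains open. The same holds for pyridin-3-yl on the double-bonded chain carbon.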